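Chalcone series: pyridin-2-yl for phenyl on the chain

The source may hold more compounds than are shown below. What is called first, only, known or untested is meant among the compounds shown, and "the series" means these compounds.

Compound 2 has the structure `COc1ccc(C(=O)/C=C/c2ccccc2)c2c1C=CC(C)(C)O2`. In a functional assay on K562 cells (Homo sapiens) for antiproliferative activity, read by MTT assay, with a stated time of 24 h (on this read-out lower numbers stand for stronger inhibition and higher numbers for weaker inhibition), compound 2 gives > 10000 nM, which is a limit of the assay and not a number. Within the data shown here, the only other measured member, compound 1 with structure `COc1ccc(/C=C/C(=O)c2ccc(OC)c3c2OC(C)(C)C=C3)c(F)c1`, gives in this assay > 10000 nM, likewise a limit. The step from these two, a step that the two limits leave unreadable from compound 1 to compound 2, cannot be read in size or direction, so the position of compound 2 on the numbers shown is that of a compound sitting at the limit of > 10000 nM in this assay, at which 2 of the 2 values shown sit, with no graded value to anchor it.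

The next member, compound 3 with structure `COc1ccc(C(=O)/C=C/c2ccccn2)c2c1C=CC(C)(C)O2`, differs from compound 2 in one place: pyridin-2-yl in place of phenyl on a double-bonded chain carbon bound to a double-bonded chain carbon. Among the measured compounds shown here, no measured step touches this change; the single step known, from an aryl exchange on the same chain carbon, was itself unreadable. The expectation therefore rests on compound 2 alone. Compound 3 is expected to stay near the limit, with an estimated value of 12000 nM and a range from 3000 nM to 50000 nM. The expected step that the limit leaves unreadable from compound 2 to compound 3 is taken as none beyond the scatter, pending measurement.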

Compound 3, half-maximal inhibitory concentration: 5400 nM
For compound 3 the middle estimate is 2.2-fold (0.35 log units) above the measured one; low and high end bracket the measured number.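

In this assay compound 3 gives 5400 nM, the only graded number among the compounds shown, so pyridin-2-yl on this chain carbon is the one aryl group here that yields a readable value. Exchanging phenyl for pyridin-2-yl gives an at least 1.8-fold lower number from compound 2 to compound 3 (0.26 log units; that floor lies within the scatter), and exchanging 2-fluoro-4-methoxyphenyl for pyridin-2-yl gives an at least 1.8-fold lower number from compound 1 to compound 3 (0.26 log units; that floor lies within the scatter); both are floors, so neither establishes a step beyond the scatter, though the true size of either may be larger. Compound 1 and compound 2 each remain at a limit of the assay and not at a number: the limit of > 10000 nM in this assay, at which 2 of the 3 values shown sit.

Going by these compounds, whether the ring nitrogen of pyridin-2-yl is what matters on this chain carbon stays open, as does the question of how an imidazolyl ring or an aminophenyl group would read there. Also open, on these data alone, is whether the pyridin-2-yl exchange would give a graded number on a core carrying a carboxylic acid or a longer chain in place of the methoxy group.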